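Swapping the difluorophenyl ring for a methoxypyridine

The compounds below may be only part of what the source reports. "The series", "measured", "known", "first", "only" and "open" are said of these compounds alone.

Of the compounds shown here, two have been measured in an in vitro assay on HEK385-7 cells for displacement of a labelled ligand from prostaglandin D2 receptor 2 (Homo sapiens); on this read-out lower numbers stand for stronger inhibition and higher numbers for weaker inhibition. Compound 1, with structure `O=C(O)Cc1sc(C(c2ccccc2)c2ccccc2)nc1-c1ccccc1`, carries three plain phenyl rings on its shared core and gives 570 nM in this assay. Compound 2, with structure `O=C(O)Cc1sc(C(c2ccc(F)cc2)c2ccc(F)cc2)nc1-c1cc(F)cc(F)c1`, carries fluorine on all three rings and gives 35 nM in this assay. Among the two numbers measured so far, compound 2 has the lowest, and its distance from compound 1 lies beyond the usual scatter.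

Compound 3, with structure `COc1cc(-c2nc(C(c3ccc(F)cc3)c3ccc(F)cc3)sc2CC(=O)O)ccn1`, is not yet measured. It differs from compound 2 in one place: 2-methoxypyridin-4-yl in place of 3,5-difluorophenyl on an aromatic carbon. The rest of the molecule, including the two fluorophenyl rings on the large group and the carboxymethyl group, stays the same.

Among the measured compounds shown here, no measured pair shows what such a change does here, so the expectation rests on the two values alone. Because compound 2 gives 35 nM, the estimate for compound 3 is a modest step toward weaker binding, roughly a 2.3-fold higher number from compound 2 to compound 3 (0.36 log units; beyond the scatter), with a wide uncertainty. Compound 3 is expected to give about 80 nM in this assay, in a range from 20 nM to 350 nM.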

Compound 3, half-maximal inhibitory concentration: 29 nM
For compound 3 the middle estimate is 2.8-fold (0.44 log units) above the measured one; the range from low to high includes it.
By their numbers in this assay, from the lowest: compounds 3 and 2 (each within the scatter of the next); then compound 1.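

In this assay the swap of 3,5-difluorophenyl for 2-methoxypyridin-4-yl gives a 1.2-fold lower number from compound 2 to compound 3 (0.08 log units; within the scatter), so at this ring carbon the two groups cannot be told apart. The entering ring has no fluorine and counts 2 hydrogen-bond acceptors against 0 for the leaving ring, so a number of this size at this position does not depend on fluorine on this ring, at least with the two fluorophenyl rings and the carboxymethyl group kept in place. Nothing shown here gives a reason why these two different rings read alike.

Going by these compounds, it stays open whether the ring nitrogen or the methoxy group matters more in compound 3, a question that a pyridine ring without the methoxy group, or a phenyl ring carrying a methoxy group, would address, and whether an amine or a longer ethoxy chain in place of the methoxy group would fare as well. On these data alone, compound 1 and compound 2 differ on all three rings, so the share of the fluorine on each ring in the gap between them also remains unknown.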